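A few compounds are considered here, and "the series" means these few. Any claim that something is new, unique, unknown or untested is made for them only; others in the source may bear on it.

Of the compounds shown here, three with the same core have been measured in an assay on HEK-293T cells for antagonist activity at vitamin D3 receptor (Homo sapiens), read by a luciferase reporter, with a stated time of 24 h; a higher number here means a weaker inhibitor, a lower number a stronger inhibitor. Compound 2 `CC(C)c1onc(-c2c(Cl)cccc2Cl)c1COc1ccc(-c2nc3ccc(C(=O)O)cc3n2CC(C)(C)C)cc1` gives 861 nM, the lowest of the three numbers. Compound 3 `CC(C)c1onc(-c2c(Cl)cccc2Cl)c1COc1ccc(-c2nc3ccc(C(=O)O)cc3n2CC2CC2)cc1` gives 2650 nM, and compound 1 `CC(C)c1onc(-c2c(Cl)cccc2Cl)c1COc1ccc(-c2nc3cc(C(=O)O)ccc3n2C)cc1` gives 4410 nM; compound 1 differs from compound 2 in more than one place, so its two values are simply set side by side. For the measured compounds named here, the one single-point step among them is a 3.1-fold higher number from compound 2 to compound 3 (0.49 log units; beyond the scatter).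

Compound 4 `CC(C)Cn1c(-c2ccc(OCc3c(-c4c(Cl)cccc4Cl)noc3C(C)C)cc2)nc2ccc(C(=O)O)cc21` is built from compound 2 by the change (hydrogen in place of methyl on a saturated chain carbon bound to three saturated chain carbons), that is, from tert-butyl to isopropyl, or from neopentyl to isobutyl on the chain that carries the aromatic nitrogen. Going by the values given here, the only step that bears on it is the one from compound 2 to compound 3, where cyclopropyl replaced tert-butyl on the same chain carbon and the number rose by a modest amount. The change to compound 4 is smaller in kind than that one, since only one carbon of the tert-butyl is removed, so the step is expected to be smaller as well, in the same upward direction or not beyond the scatter. The expected step is a 1.6-fold higher number from compound 2 to compound 4 (0.21 log units; within the scatter). Compound 4 is therefore estimated at 1400 nM in this assay, with a range from 600 nM to 3500 nM.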

Compound 4, half-maximal inhibitory concentration: 1180 nM
The estimate for compound 4 lay 1.2-fold (0.07 log units) above the measured number, and the stated range covers the measured number.
By their numbers in this assay, from the lowest: compounds 2 and 4 (each within the scatter of the next); then compounds 3 and 1 (each within the scatter of the next).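

In this assay, cutting the tert-butyl down to isopropyl moves the number only by a 1.4-fold higher number from compound 2 to compound 4 (0.14 log units; within the scatter), so one methyl on this saturated chain carbon can be removed with no change that the assay can resolve, and neopentyl and isobutyl cannot be told apart here. The cyclopropyl group now stands apart from both branched groups: besides the earlier step to it from tert-butyl, isopropyl in its place gives a 2.2-fold lower number from compound 3 to compound 4 (0.35 log units; beyond the scatter), which shows that among these three groups, the result depends on more than the removal of a carbon from the tert-butyl. None of the available data offers an explanation for why cyclopropyl differs from the two open branched groups.

On these data alone, whether the number stays level with an unbranched chain such as n-butyl, or with a chain that carries an amine or a hydroxyl group, remains open for this saturated chain carbon bound to an aromatic nitrogen. As far as these compounds go, compound 1, at 4410 nM, differs from compound 2 in more than one place, so the effect of a methyl alone on the aromatic nitrogen also remains open.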